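A few compounds are considered here, and "the series" means these few. Any claim that something is new, unique, unknown or untested is made for them only; others in the source may bear on it.

Of the compounds shown here, two have been measured so far, and they share a common core. Compound 1 `Cc1cc(Nc2cc(-c3ccccc3)[nH]n2)n2nc(SCc3cccc(Br)c3)nc2n1` carries a (3-bromobenzyl)sulfanyl group on that core. In an ADME assay on GES1 cells (Homo sapiens) for inhibition, read by MTT assay, with a stated time of 72 h (a higher number here means a weaker inhibitor, a lower number a stronger inhibitor), compound 1 gives only a limit of the assay, > 50000 nM. So where compound 1 stands is known only as the limit of > 50000 nM in this assay, at which 1 of the 2 values shown sits. Within the data shown here, compound 2 `Cc1cc(Nc2ccn(Cc3nc(C)c4ccccc4n3)n2)n2nc(SCc3ccc(Br)cc3)nc2n1` differs from compound 1 at more than one place, so no single step between them can be read; in this assay compound 2 gives 36800 nM.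

Compound 3 `CCCSc1nc2nc(C)cc(Nc3cc(-c4ccccc4)[nH]n3)n2n1` has not yet been measured. It differs from compound 1 in one place: ethyl in place of 3-bromophenyl on a saturated chain carbon bound to a sulfur. Among the measured compounds shown here, since compound 1 stands only at a limit, no measured step shows how this assay responds to such a change. From compound 1 to compound 3 the expected step is a step that the limit leaves unreadable from compound 1 to compound 3, which amounts to no change beyond the usual scatter, with a fair chance that the assay again reports only a limit. Compound 3 is therefore expected to give about 70000 nM in this assay, with a range from 30000 nM to 200000 nM.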

Compound 3, half-maximal inhibitory concentration: > 50000 nM
Compound 3: no number, only a limit (the forecaster's own chance of this, stated with the estimate: 70%); the middle value is on the limit's open side.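

In this assay, compound 1 and compound 3 each give only a limit, not a number, so no step between them can be read: the limit of > 50000 nM in this assay, at which 2 of the 3 values shown sit.

The compounds shown leave open whether replacing 3-bromobenzyl with propyl changes the result in this assay at all, and in which direction.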